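Furan for pyridine on the shared aminopyrimidine core

This account rests on a few compounds, and the source may have more. Where it says the series, first, only, none or still open, it means among the compounds named here.

Measured so far in a functional assay for inhibition, with Homo sapiens as the target; on this read-out lower numbers stand for stronger inhibition and higher numbers for weaker inhibition:
- compound 1, `Cc1cc(-c2ccccn2)nc(Nc2ccc(N(C)C)cc2)n1`, gives 31900 nM
- compound 2, `Cc1cc(-c2ccco2)nc(Nc2ccc(N(C)C)cc2)n1`, gives 5900 nM
- compound 3, `c1ccc(-c2ccnc(Nc3ccc(-n4ccnc4)cc3)n2)nc1`, gives 1400 nM

Among the measured compounds shown here, the one counted step is furan-2-yl in place of pyridin-2-yl on an aromatic carbon, giving a 5.4-fold lower number from compound 1 to compound 2 (0.73 log units; beyond the scatter). Compound 3 stands at the lowest number of the three; against compound 2 the gap is beyond the scatter, as is the gap against compound 1. How the core of compound 3 differs from the core of compound 1 is not broken down here.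

Compound 4, `c1coc(-c2ccnc(Nc3ccc(-n4ccnc4)cc3)n2)c1`, is not yet measured. It is the same kind of change as compound 1 to compound 2, (furan-2-yl in place of pyridin-2-yl on an aromatic carbon); the place differs only in that compound 1 also carries a methyl group meta to it. For compound 4 in this assay a step like a 3.5-fold lower number from compound 3 to compound 4 (0.54 log units; beyond the scatter) is expected, resting on the step from compound 1 to compound 2 a 5.4-fold lower number from compound 1 to compound 2 (0.73 log units; beyond the scatter) in the same direction, with the core difference leaving its size uncertain. Compound 4 is estimated at 400 nM, between 150 nM and 1200 nM.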

Compound 4, half-maximal inhibitory concentration: 2200 nM
For compound 4 the middle estimate is 5.5-fold (0.74 log units) below the measured one; measured number outside the range, above it.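

On the core of compound 3, furan-2-yl in place of pyridin-2-yl gives a 1.6-fold higher number from compound 3 to compound 4 (0.20 log units; within the scatter) in this assay, so the drop in the number seen on the core of compound 1 does not carry over. The size of this change varies with the core, and the two steps differ: the same change on two cores in this assay, a 5.4-fold lower number (0.73 log units; beyond the scatter) from compound 1 to compound 2 and a 1.6-fold higher number (0.20 log units; within the scatter) from compound 3 to compound 4, 8.5-fold (0.93 log units) apart, beyond the scatter of two such steps. The cores differ in more than one place, so these pairs do not show which difference matters, and two pairs set no rule for the series.

Open, as far as these compounds go, is whether the methyl group of compound 1 or the other difference between the cores accounts for the gap. Also open, from the compounds shown here alone, is how a small amine or a carboxylic acid in the same place would read in this assay.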